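This account rests on a few compounds, and the source may have more. Where it says the series, first, only, none or still open, it means among the compounds named here.

Compound 1 `COc1ccc(OC)c(/C=C/c2nnc(Nc3ccc(Cl)cc3)o2)c1`: 78000 nM
Compound 2 `COc1ccc(OC)c(/C=C/C(=O)N/N=C/c2ccc(Cl)cc2)c1`: > 100000 nM

In a functional assay on UO-31 cells (Homo sapiens) for antiproliferative activity, read by sulforhodamine B assay, with a stated time of 48 h (on this read-out lower numbers stand for higher toxicity in this test and higher numbers for lower toxicity in this test), compound 1 gives 78000 nM. Compound 2 reaches only a limit of the assay, at > 100000 nM, so no number is known for it. Compound 2 thus sits at the weaker end of the two values shown, which is described by the limit of > 100000 nM in this assay, at which 1 of the 2 values shown sits. Within the data shown here, no measured step between these two compounds is available, because they differ in more than one place.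

Compound 3 `COc1ccc(OC)c(/C=C/C(=O)N/N=C/c2ccccc2)c1` differs from compound 2 by hydrogen in place of chloro on an aromatic carbon. Since compound 2 is known only as a limit, the step in this assay cannot be set against any measured change of the same kind. No step beyond the scatter is expected, and the estimated change is a step that the limit leaves unreadable from compound 2 to compound 3. For compound 3 the estimate is therefore 150000 nM in this assay, with a range from 60000 nM to 400000 nM, and most likely again reported only as a limit.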

Compound 3, concentration lethal to 50% of the cells: > 100000 nM
Compound 3 was reported as a limit; the forecaster's own chance of this, stated with the estimate: 75%; the middle value does not contradict the limit.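

In this assay compound 2 and compound 3 are both known only as limits of the assay, so no step can be read between them. The compounds shown leave open whether phenyl in place of 4-chlorophenyl changes the toxicity in this test at all.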